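From compound 3 to compound 4: a benzyl swap

This account rests on a few compounds, and the source may have more. Where it says the series, first, only, none or still open, it means among the compounds named here.

compound 1 `C#CCOc1ccc2c(=O)c(-c3cc(OC)c(OC)cc3OC)coc2c1`: 6450 nM
compound 2 `COc1cc(OC)c(-c2coc3cc(OCc4ccc([N+](=O)[O-])cc4)ccc3c2=O)cc1OC`: 9400 nM
compound 3 `COc1cc(OC)c(-c2coc3cc(OCc4ccccc4C(F)(F)F)ccc3c2=O)cc1OC`: > 10000 nM (a limit of the assay, not a number)

All three compounds share one core and were tested in a functional assay on U-251 cells (Homo sapiens) for antiproliferative activity, read by MTT assay, with a stated time of 24 h (a lower number here means a stronger inhibitor, a higher number a weaker inhibitor), for their effect on these cells.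

Compound 3 stands at > 10000 nM, which is a limit and not a measured number.

Compound 4 `COc1cc(OC)c(-c2coc3cc(OCc4ccc(Cl)cc4)ccc3c2=O)cc1OC` has not yet been measured. It differs from compound 3 in one place: 4-chlorophenyl in place of 2-(trifluoromethyl)phenyl on a saturated chain carbon bound to an oxygen on an aromatic ring. Put simply, 2-(trifluoromethyl)benzyl gives way to 4-chlorobenzyl.

Three measured steps changed the group at this same place. Replacing ethynyl with 4-nitrophenyl gave a 1.5-fold higher number from compound 1 to compound 2 (0.16 log units; within the scatter). Replacing ethynyl with 2-(trifluoromethyl)phenyl gave an at least 1.5-fold higher number from compound 1 to compound 3 (0.19 log units; that floor lies within the scatter). Exchanging the two substituted phenyl groups gave an at least 1.0-fold higher number from compound 2 to compound 3 (0.02 log units; that floor lies within the scatter). None of these exceeds the scatter, though the last two are only floors.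

In this assay no step beyond the scatter is therefore expected, and no direction can be called with confidence. The nearest guide is compound 2 at 9400 nM, whose 4-nitrophenyl group stands where compound 4 carries 4-chlorophenyl.

The estimated value for compound 4 is 8500 nM, with an expected range from 4000 nM to 18000 nM here.

The expected step is an at least 1.1-fold lower number from compound 3 to compound 4 (0.07 log units; that floor lies within the scatter) as estimated.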

Compound 4, half-maximal inhibitory concentration: 470 nM
Beside the measured number, compound 4's estimate is 18-fold (1.26 log units) above it; measured number outside the range, below it.
By their numbers in this assay, from the lowest: compound 4; then compounds 1 and 2 (each within the scatter of the next). At a limit, above all of these: compound 3.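

Going by these compounds alone, until now no measured step at this place, on a saturated chain carbon bound to an oxygen on an aromatic ring, had gone beyond the scatter in this assay, but 4-chlorobenzyl changes that, with a 14-fold lower number from compound 1 to compound 4 (1.14 log units; beyond the scatter). A substituted phenyl alone does not account for this, since swapping only chloro for nitro on an aromatic carbon gives a 20-fold lower number from compound 2 to compound 4 (1.30 log units; beyond the scatter), and the change from 2-(trifluoromethyl)phenyl to 4-chlorophenyl gives an at least 21-fold lower number from compound 3 to compound 4 (1.32 log units; beyond the scatter). Compound 3 stands at a limit of the assay and not at a measured number, so the true size of that last step remains unknown: the limit of > 10000 nM in this assay, at which 1 of the 4 values shown sits.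

On these data alone, it remains open whether the gain belongs to chloro itself or would also come with another group, such as bromo, fluoro or methoxy, in its place on the phenyl ring, or with an unsubstituted benzyl. A 2-chlorobenzyl group would also show how much depends on the chloro group and how much on where it stands on the ring, which the compounds shown cannot separate.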